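The compounds below may be only part of what the source reports. "The series", "measured", "known", "first", "only" and "open" are said of these compounds alone.

Measured compounds in a functional assay on HCT-116 cells (Homo sapiens) for antiproliferative activity, read by MTT assay, with a stated time of 48 h; on this read-out lower numbers stand for stronger inhibition and higher numbers for weaker inhibition:

compound 1 `COc1ccc(CN(C(=O)CSc2nc3ccccc3s2)c2cc(OC)c(OC)c(OC)c2)cc1F` gives 1830 nM
compound 2 `COc1ccc(CN(C(=O)CSc2nc3ccccc3s2)c2cc(OC)c(OC)c(OC)c2)cc1N` gives 491 nM
compound 3 `COc1ccc(CN(C(=O)CSc2nc3ccccc3s2)c2cc(OC)c(OC)c(OC)c2)cc1N=[N+]=[N-]` gives 2860 nM

Compound 3 gives the highest number of the three in this assay, which means the weakest inhibition seen here. The step of a 1.6-fold higher number from compound 1 to compound 3 (0.19 log units; within the scatter) is within the scatter, so compound 1 and compound 3 cannot be told apart; the step of a 5.8-fold higher number from compound 2 to compound 3 (0.77 log units; beyond the scatter) is beyond it, so compound 2 is the only one that stands clearly lower.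

Compound 4 `COc1ccc(CN(C(=O)CSc2nc3ccccc3s2)c2cc(OC)c(OC)c(OC)c2)cc1Br` differs from compound 3 in one place: bromo in place of azido on an aromatic carbon. Among the compounds with values here, no measured step swaps azido for bromo. Within the data shown here, the steps that bear on it are the two at the same aromatic carbon: fluoro to amino, a 3.7-fold lower number from compound 1 to compound 2 (0.57 log units; beyond the scatter), a modest lowering, and fluoro to azido, a 1.6-fold higher number from compound 1 to compound 3 (0.19 log units; within the scatter), within the scatter. Bromo, like the azido it replaces and unlike the amino of compound 2, brings no hydrogen-bond donor, so compound 4 is expected to sit close to compound 3, with the step of a 1.4-fold lower number from compound 3 to compound 4 (0.16 log units; within the scatter) expected to stay within the scatter. Compound 4 is therefore estimated at 2000 nM, with a range from 800 nM to 5000 nM.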

Compound 4, half-maximal inhibitory concentration: 4550 nM
The estimate for compound 4 lay 2.3-fold (0.36 log units) below the measured number; the measured number falls inside the stated range.
By their numbers in this assay, from the lowest: compound 2; then compounds 1, 3 and 4 (each within the scatter of the next, the first and the last beyond it).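

In this assay, bromo in place of azido on this aromatic carbon gives a 1.6-fold higher number from compound 3 to compound 4 (0.20 log units; within the scatter), so the two groups cannot be told apart here, although azido has 3 heavy atoms and bromo has 1. Bromo and fluoro, however, can be told apart at this carbon, with bromo in place of fluoro giving a 2.5-fold higher number from compound 1 to compound 4 (0.40 log units; beyond the scatter), while bromo in place of amino gives a 9.3-fold higher number from compound 2 to compound 4 (0.97 log units; beyond the scatter), which leaves compound 2 as the only one of the four clearly lower than all the others. Nothing measured here accounts for these differences.

The compounds shown leave open whether a hydroxyl or a methylamino group on this carbon would match the low number of the amino group in compound 2. They also leave open whether a chloro group would stand with fluoro, with bromo or with neither.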